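Ring-fused lactam series: N-substituent removal on MCF7

A few compounds are considered here, and "the series" means these few. Any claim that something is new, unique, unknown or untested is made for them only; others in the source may bear on it.

Measured so far:
compound 1 `COc1ncc(-c2ccc3c(c2)NC(=O)CO3)cc1NS(=O)(=O)c1ccc(F)cc1` — 32300 nM
compound 2 `COc1cccc(N2C(=O)COc3ccc(-c4cnc(OC)c(NS(=O)(=O)c5ccc(F)cc5)c4)cc32)c1` — > 40000 nM
compound 3 `COc1cccc(N2C(=O)COc3ccc(-c4ccc(O)cc4)cc32)c1` — > 40000 nM

In a functional assay on MCF7 cells (Homo sapiens) for antiproliferative activity, read by MTT assay, with a stated time of 72 h (on this read-out higher numbers stand for weaker inhibition and lower numbers for stronger inhibition), compound 1 gives 32300 nM. Compound 2 reaches only the limit of this assay, > 40000 nM. Compound 3 likewise reaches only the limit, > 40000 nM. Within the data shown here, the one measured step, an at least 1.2-fold lower number from compound 2 to compound 1 (0.09 log units; that floor lies within the scatter), is the change (hydrogen in place of 3-methoxyphenyl on an amide-type nitrogen in a ring); its floor rests on (the limit of > 40000 nM in this assay, at which 2 of the 3 values shown sit). The cores of compound 2 and compound 3 differ in more than one place, and that difference is not broken down here.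

Compound 4 `O=C1COc2ccc(-c3ccc(O)cc3)cc2N1` is not yet measured. It stands to compound 3 as compound 1 stands to compound 2: the change (hydrogen in place of 3-methoxyphenyl on an amide-type nitrogen in a ring), the same kind of change at the same kind of place. For compound 4 a step of an at least 1.1-fold lower number from compound 3 to compound 4 (0.05 log units; that floor lies within the scatter) is expected, on the ground that compound 3 gives only the limit > 40000 nM and the earlier step of an at least 1.2-fold lower number from compound 2 to compound 1 (0.09 log units; that floor lies within the scatter) was small. Compound 4 is estimated at 35000 nM in this assay, with a range from 15000 nM to 80000 nM.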

Compound 4, half-maximal inhibitory concentration: > 40000 nM
Compound 4: a limit, no number; the forecaster's own chance of this, stated with the estimate: 50%; at least 1.1-fold (0.05 log units) between middle value and limit.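

In this assay compound 4 gives > 40000 nM, a limit and not a number. Compound 3 also stands at a limit, so no step can be read between compound 3 and compound 4: the limit of > 40000 nM in this assay, at which 3 of the 4 values shown sit.

The compounds shown leave open whether hydrogen in place of 3-methoxyphenyl changes the read-out at all in this pair.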